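The source may hold more compounds than are shown below. What is called first, only, known or untested is meant among the compounds shown, and "the series" means these compounds.

Measured compounds:
- compound 1, `COc1ccc(C2=NN(C3=NC(=O)/C(=C4\C(=O)Nc5ccc(Cl)cc54)S3)C(c3ccc(OC)cc3)C2)cc1`: 440 nM
- compound 2, `COc1ccc(C2=NN(C3=NC(=O)/C(=C4\C(=O)Nc5ccc(Br)cc54)S3)C(c3ccc(Cl)cc3)C2)cc1`: 340 nM

In a functional assay on cells (Cancer cell lines, Homo sapiens) for cytotoxicity, read by sulforhodamine B assay, with a stated time of 48 h (a higher number here means a weaker inhibitor of growth, a lower number a stronger inhibitor of growth), compound 1 gives 440 nM and compound 2 gives 340 nM. Compound 2 stands at the lowest of the two numbers, with compound 1 as its nearest neighbour, and the gap between them lies within the scatter, so the two compounds are not separated by these data.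

Compound 3, `COc1ccc(C2=NN(C3=NC(=O)/C(=C4\C(=O)Nc5ccc(Cl)cc54)S3)C(c3ccc(Cl)cc3)C2)cc1`, has not yet been measured in this assay. It differs from compound 2 by chloro in place of bromo on an aromatic carbon. Among the compounds with values here, no pair of measured compounds differing in a single place is available, so the step has no measured counterpart. The change is expected to move the number only a little, in no particular direction, and not beyond the scatter. The step from compound 2 to compound 3 is estimated as a 1.2-fold higher number from compound 2 to compound 3 (0.07 log units; within the scatter). Compound 3 is expected to give 400 nM in this assay, with a range from 200 nM to 800 nM.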

Compound 3, concentration for total growth inhibition: 460 nM
Estimate against measurement, compound 3: 1.2-fold (0.06 log units) below; the measured number falls inside the stated range.
By their numbers in this assay, from the lowest: compounds 2, 1 and 3 (each within the scatter of the next).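

In this assay, within the data shown here, the first single-place reading at the halogen site on the fused system gives a 1.4-fold higher number from compound 2 to compound 3 (0.13 log units; within the scatter), so chloro and bromo on this aromatic carbon are not separated by these data. A second place can now be read as well: exchanging the methoxy there for chloro gives a 1.0-fold higher number from compound 1 to compound 3 (0.02 log units; within the scatter), and that swap also leaves the number within the scatter. No accompanying data bear on either result.

From the compounds shown here alone, whether either place responds to a group of another kind, such as an amine or a carboxylic acid, stays open, since only bromo, chloro and methoxy appear there. The methoxy common to all three compounds also remains unprobed, so its contribution to the shared level of activity cannot be read.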